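The source may report more compounds than this note shows. Statements on the series, on what has been measured and on what is new or still open speak of the compounds shown alone.

Measured in a functional assay on Hs68 cells (Homo sapiens) for cytotoxicity; a lower number here means that less compound is tolerated, a higher number that more compound is tolerated:
compound 1 `CC(C)Oc1ccccc1CNC(=O)c1ccc2cncc(Br)c2n1`: 9 ug/mL
compound 2 `CC(C)Oc1ccccc1CNC(=O)c1ccc2cncc(Cl)c2n1`: 6 ug/mL
compound 3 `O=C(NCc1ccc(Br)cc1)c1ccc2cnccc2n1`: 10 ug/mL

In this assay compound 3 gives 10 ug/mL, which lies within the scatter of the values of both compound 1 and compound 2. The next compound is compound 4 `O=C(NCc1ccccc1)c1ccc2cnccc2n1`, with hydrogen in place of bromo on an aromatic carbon, para to a large group: hydrogen in place of bromo on an aromatic carbon.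

Going by the values given here, only one measured step bears on this change: a 1.5-fold lower number from compound 1 to compound 2 (0.18 log units; within the scatter). That step is within the scatter, but it swaps one halogen for another on the core of compound 1, so it is only a loose guide. Among the compounds with values here, no measured step removes a halogen outright, and none changes this ring. No step beyond the scatter is therefore expected in this assay, and the data give no firm direction. The expected change is a 1.2-fold higher number from compound 3 to compound 4 (0.08 log units; within the scatter). For compound 4 the estimated value is 12 ug/mL, with an expected range of 5 ug/mL to 30 ug/mL.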

Compound 4, half-maximal cytotoxic concentration: 71 ug/mL
For compound 4 the middle estimate is 5.9-fold (0.77 log units) below the measured one, and the stated range ends below it.
By their numbers in this assay, from the lowest: compounds 2, 1 and 3 (each within the scatter of the next); then compound 4.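

Removing the bromo from the 4-bromophenyl group gives a 7.1-fold higher number from compound 3 to compound 4 (0.85 log units; beyond the scatter) in this assay so this position, para to a large group, clearly affects the number, and more compound is tolerated with hydrogen there. Going by these compounds alone, the only earlier step, a 1.5-fold lower number from compound 1 to compound 2 (0.18 log units; within the scatter), exchanged one halogen for another on the core of compound 1 and gave no sign that a single substituent could shift the number this far. No measured evidence explains the size of this change.

Going by these compounds, it remains open whether this shift is specific to the bromo or would follow the loss of any group at this place, which a fluoro, a methoxy or an amine there would help to separate. On these data alone, it is also open whether replacing the bromo on the core of compound 1 with hydrogen would produce a comparable step.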